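Extending a Methyl Group on a Pyrazole Nitrogen

The source may report more compounds than this note shows. Statements on the series, on what has been measured and on what is new or still open speak of the compounds shown alone.

Measured so far:
- compound 1, `Cc1ccc(C(=O)Nc2cccc(C(F)(F)F)c2)cc1-c1ccc2c(-c3ccc(C(=O)N4CCN(C)CC4)cc3)n[nH]c2c1`: 6.5 nM
- compound 2, `Cc1ccc(C(=O)Nc2cccc(C(F)(F)F)c2)cc1-c1ccc2c(-c3cnn(C)c3)n[nH]c2c1`: 4.4 nM

Both compounds were tested in an assay on isolated protein for inhibition of Discoidin domain-containing receptor 2 (Homo sapiens), read by ELISA, with a stated time of 60 min; on this read-out lower numbers stand for stronger inhibition and higher numbers for weaker inhibition. In this assay compound 1 gives 6.5 nM and compound 2 gives 4.4 nM. Compound 2 has the lower of the two numbers, yet the gap to compound 1 lies within the usual scatter of repeated measurements, so the two results cannot be told apart with confidence. Among the measured compounds shown here, the two compounds differ in the group attached to the shared core, and no single-point step between them is available, so only the two values themselves can be compared.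

Compound 3, `CCCn1cc(-c2n[nH]c3cc(-c4cc(C(=O)Nc5cccc(C(F)(F)F)c5)ccc4C)ccc23)cn1`, has not yet been measured. It differs from compound 2 by ethyl in place of hydrogen on a saturated chain carbon bound to an aromatic nitrogen, that is, the methyl on the pyrazole nitrogen becomes a propyl. For the measured compounds named here, since no measured pair shows the effect of such a chain extension here, the step from compound 2 to compound 3 is expected to be a 1.3-fold higher number from compound 2 to compound 3 (0.10 log units; within the scatter), with no change beyond the scatter in either direction. Compound 3 is therefore estimated at 5.5 nM, within a range from 2 nM to 15 nM.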

Compound 3, half-maximal inhibitory concentration: 3.2 nM
Compound 3: the middle estimate sits 1.7-fold (0.24 log units) above what was measured; measured number inside the range.
By their numbers in this assay, from the lowest: compounds 3, 2 and 1 (each within the scatter of the next, the first and the last beyond it).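

In this assay the methyl on the pyrazole nitrogen becomes a propyl with no change that can be told from the scatter (a 1.4-fold lower number from compound 2 to compound 3 (0.14 log units; within the scatter)). Compounds 1 and 2 differ in the whole group attached to the shared core, so they could not isolate a change of this kind. Among the compounds shown here, this pair is the first direct reading of one. Only this chain differs within the pair. It shows that, for this pair, going from 1-methyl-1H-pyrazol-4-yl to 1-propyl-1H-pyrazol-4-yl, with ethyl in place of hydrogen on a saturated chain carbon bound to an aromatic nitrogen, leaves the read-out where it was, and nothing measured here explains why.

From the compounds shown here alone, whether this holds for a longer chain such as butyl or hexyl, or for a branched one such as isopropyl, remains open. Going by these compounds, it is equally open whether a propyl chain ending in an amine or a carboxylic acid would give a similar number, since one step on one pair cannot establish a trend.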